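One Swap on a Shared Core, All Values at a Limit

The source may report more compounds than this note shows. Statements on the series, on what has been measured and on what is new or still open speak of the compounds shown alone.

Measured so far in a functional assay on CHO cells for agonist activity at Alpha-1D adrenergic receptor (Homo sapiens), read by FLIPR and calcium flux; a higher number here means that more compound is needed for the effect, a lower number that less compound is needed:
Compound 1, `c1ccc(-c2cccc3c2CCC3c2ncc[nH]2)nc1`, is reported only as a limit, > 10000 nM.
Compound 2, `CCCS(=O)(=O)Nc1cccc2c1CCC2c1ncc[nH]1`, is reported only as a limit, > 10000 nM.
Compound 3, `Cc1c(OCC2=NCCN2)ccc(Cl)c1NS(C)(=O)=O`, is reported only as a limit, > 10000 nM.

Compound 1 stands where every value shown stands, at a limit rather than at a number: the limit of > 10000 nM in this assay, at which 3 of the 3 values shown sit. Compound 4, `CNC(=O)c1cccc2c1CCC2c1ncc[nH]1`, differs from compound 1 in one place: methylcarbamoyl in place of pyridin-2-yl on an aromatic carbon. For the measured compounds named here, the only measured step on the shared core that bears on this change is a step that the two limits leave unreadable from compound 1 to compound 2, and its size is unreadable, both of its ends sitting at a limit. Going by the values given here, no measured step gives a readable size in either direction, so there is no basis for expecting a change beyond the scatter, and the most likely outcome is that the assay again reports only a limit. The step expected from this reasoning is a step that the limit leaves unreadable from compound 1 to compound 4. Compound 4 is therefore estimated at 15000 nM, with an expected range from 3000 nM to 60000 nM.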

Compound 4, half-maximal effective concentration: > 10000 nM
Compound 4: only a limit was reported; the forecaster's own chance of this, stated with the estimate: 80%; the middle value lies beyond the limit too.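

Compound 4 is reported only as a limit in this assay, so its steps from compound 1 and from compound 2 cannot be read, since all three compounds sit at the same limit: the limit of > 10000 nM in this assay, at which 4 of the 4 values shown sit.

The compounds shown leave open whether any group at this place on the shared core would give a readable value in this assay.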